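A few compounds are considered here, and "the series" means these few. Any claim that something is new, unique, unknown or untested is made for them only; others in the source may bear on it.

In a functional assay on CRL2813 cells (Homo sapiens) for cytotoxicity, read by sulforhodamine B assay, with a stated time of 5 days (a higher number here means a weaker inhibitor, a lower number a stronger inhibitor), the three measured ureas stay close together at weak potency. Compound 1 `COC(=O)c1ccc(NC(=O)N[C@H]2CC[C@H](Oc3ccc(F)cc3)CC2)cc1` gives 11600 nM. Compound 2 `O=C(Nc1cccc(F)c1)N[C@H]1CC[C@H](Oc2ccc(F)cc2)CC1` gives 8300 nM. Compound 3 `COc1ccc(NC(=O)N[C@H]2CC[C@H](Oc3ccc(F)cc3)CC2)cc1` reaches only the limit of the assay at > 20000 nM, so no exact number is known for it. Among the numbers shown, compound 3 therefore stands at the weak end, and its value is a limit because of the limit of > 20000 nM in this assay, at which 1 of the 3 values shown sits.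

Two steps lead into compound 3: an at least 1.7-fold higher number from compound 1 to compound 3 (0.23 log units; that floor lies within the scatter) and an at least 2.4-fold higher number from compound 2 to compound 3 (0.38 log units; beyond the scatter). The second is the one that bears on the next compound. Compound 4 `O=C(Nc1cccc(Br)c1)N[C@H]1CC[C@H](Oc2ccc(F)cc2)CC1` differs from compound 3 by 3-bromophenyl in place of 4-methoxyphenyl on an amide-type nitrogen. In this way compound 4 resembles compound 2, which carries 3-fluorophenyl on the same amide-type nitrogen, rather than compound 3 with its 4-methoxyphenyl. The expectation is that exchanging 4-methoxyphenyl for a halogen-bearing phenyl undoes the loss seen from compound 2 to compound 3, so that the number in this assay falls by a modest amount, back toward the value of compound 2, although the exact size is uncertain since compound 3 itself is known only as a limit. Compound 4 is therefore estimated at 8000 nM, within a range of 3000 nM to 22000 nM, an expected step of an at least 2.5-fold lower number from compound 3 to compound 4 (0.39 log units; beyond the scatter).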

Compound 4, half-maximal inhibitory concentration: 6200 nM
Compound 4: the middle estimate sits 1.3-fold (0.11 log units) above what was measured, and the stated range covers the measured number.
By their numbers in this assay, from the lowest: compounds 4, 2 and 1 (each within the scatter of the next). At a limit, above all of these: compound 3.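

In this assay, 3-bromophenyl in place of 4-methoxyphenyl on the amide-type nitrogen gives an at least 3.2-fold lower number from compound 3 to compound 4 (0.50 log units; beyond the scatter), so a second halogen-bearing phenyl, after the 3-fluorophenyl of compound 2, stands clear of the limit reached by compound 3. Exchanging the halogen itself shows no measurable effect: bromo in place of fluoro on the aromatic carbon gives a 1.3-fold lower number from compound 2 to compound 4 (0.13 log units; within the scatter), and compound 2 and compound 4 therefore cannot be put in order. The size of the step into compound 4 from compound 3 is only a floor, because compound 3 is held at a limit: the limit of > 20000 nM in this assay, at which 1 of the 4 values shown sits.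

The compounds shown leave open whether the difference follows the halogen or the place of the substituent on the phenyl, a question that a 4-bromophenyl or a 3-methoxyphenyl on the same amide-type nitrogen would address. Also open, on these data alone, is whether an amine or a carboxylic acid on that phenyl would keep the number within the scatter of that of compound 4, at 6200 nM.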